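Nitro to acetyl on compound 1

The source may report more compounds than this note shows. Statements on the series, on what has been measured and on what is new or still open speak of the compounds shown alone.

In a physicochemical assay for lipophilicity, read by LC-MS, measured as octanol-water partition, with a stated time of 2 h, at pH 7.4, tested at 1 uM (a lower number here means a more polar compound, a higher number a more lipophilic compound), compound 1 (`O=[N+]([O-])c1ccc(-c2ccc(O[C@H]3O[C@H](CO)[C@@H](O)[C@H](O)[C@@H]3O)c(Cl)c2)cc1`) gives 2.3 and holds the lower of the two numbers available. Compound 3 (`Cc1ccccc1-c1ccc(O[C@H]2O[C@H](CO)[C@@H](O)[C@H](O)[C@@H]2O)c(Cl)c1`) stands higher at 2.9 in the same measurement. For compound 2 (`OC[C@H]1O[C@H](Oc2ccc(-c3ccc(Cl)c(Cl)c3)cc2Cl)[C@@H](O)[C@@H](O)[C@@H]1O`) the entry reads "not determined" (no result reported) and supplies no number.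

Compound 4 (`CC(=O)c1ccc(-c2ccc(O[C@H]3O[C@H](CO)[C@@H](O)[C@H](O)[C@@H]3O)c(Cl)c2)cc1`) has acetyl in place of nitro on an aromatic carbon and the same difference reads 4-nitrophenyl to 4-acetylphenyl. Within the data shown here, the one measured step at this place is a number 0.60 log units higher from compound 1 to compound 3 (beyond the scatter) with 2-methylphenyl in place of 4-nitrophenyl. That step exchanges the whole 4-nitrophenyl, whereas compound 4 differs from compound 1 only in the group para to a large group. Among the measured compounds shown here, it is the sole guide, and no measured step exchanges nitro alone. A smaller step is therefore expected here. The estimated change is a number 0.10 log units lower from compound 1 to compound 4 (within the scatter) and so no step beyond the scatter is expected in this assay for this exchange. For compound 4 the estimated value is 2.2 with an expected range from 1.8 to 2.6 in this measurement.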

Compound 4, distribution coefficient: 2.1
Estimate against measurement, compound 4: 0.10 log units above; low and high end bracket the measured number.
By their numbers in this assay, from the lowest: compounds 4 and 1 (each within the scatter of the next); then compound 3.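

Acetyl in place of nitro on an aromatic carbon, para to a large group, is the first exchange here confined to that one group. In this assay it reads as a number 0.20 log units lower from compound 1 to compound 4 (within the scatter) and so does not separate the two groups at this place. With 4-acetylphenyl in place of 2-methylphenyl the reading is a number 0.80 log units lower from compound 3 to compound 4 (beyond the scatter) and compound 3 thus stands apart from compound 1 and compound 4 alike, while no accompanying measurement explains any of these numbers.

The compounds shown leave open whether an amine or a carboxylic acid at this place would give a step beyond the scatter from compound 1. They also leave open how much of the step to compound 3 would remain with a methyl group on the same place.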